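Replacing the Methyl on the Sulfonamide with 4-Chlorophenyl

The source may report more compounds than this note shows. Statements on the series, on what has been measured and on what is new or still open speak of the compounds shown alone.

Compound 1 `CS(=O)(=O)Nc1ccc2oc(-c3ccccc3)nc2c1` was tested in an assay on cells for inhibition of HSP60/HSP10 (Homo sapiens), with a stated time of 60 min; a lower number here means a stronger inhibitor, a higher number a weaker inhibitor. In this assay compound 1 gives > 100000 nM, which is a limit of the assay rather than a number. Compound 2 `CS(=O)(=O)Nc1ccc(-c2nc3ccccc3o2)cc1` belongs to the same set. In this assay compound 2 gives > 100000 nM, again only a limit. Compound 1 therefore stands at the limit of > 100000 nM in this assay, at which 2 of the 2 values shown sit, with no measured number to compare. Compound 3 `O=S(=O)(Nc1ccc2oc(-c3ccccc3)nc2c1)c1ccc(Cl)cc1` is not yet measured; it differs from compound 1 by 4-chlorophenyl in place of methyl on a sulfonyl sulfur. Among the measured compounds shown here, no measured step shows how such a change acts here, so compound 3 is expected to stay near that limit, with a step of a number no higher from compound 1 to compound 3 (the limit leaves the size open) of about none beyond the scatter. The estimate for compound 3 is 100000 nM, ranging from 15000 nM to 300000 nM.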

Compound 3, half-maximal inhibitory concentration: > 100000 nM
Compound 3 was reported as a limit; the forecaster's own chance of this, stated with the estimate: 70%; the middle value sits exactly at the limit.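

Compound 1 and compound 3 are both reported only as limits, so no step can be read between them: the limit of > 100000 nM in this assay, at which 3 of the 3 values shown sit. With no measured number here, the compounds shown leave open whether 4-chlorophenyl in place of methyl on a sulfonyl sulfur changes inhibition at all.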